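From 3-nitrophenyl to 4-bromophenyl on a shared core

The source may report more compounds than this note shows. Statements on the series, on what has been measured and on what is new or still open speak of the compounds shown alone.

Compound 1 `COc1ccccc1-n1c(-c2coc3cc(C)c(Cl)cc3c2=O)nc(-c2ccccc2)c1-c1ccccc1` gives "not determined" (no result reported)
Compound 2 `Cc1cc2occ(-c3nc(-c4ccccc4)c(-c4ccccc4)n3-c3ccc(Cl)c(Cl)c3)c(=O)c2cc1Cl` gives 98000 nM
Compound 3 `Cc1cc2occ(-c3nc(-c4ccccc4)c(-c4ccccc4)n3-c3cccc([N+](=O)[O-])c3)c(=O)c2cc1Cl` gives "not determined" (no result reported)

These three compounds were examined in an ADME assay on MCF-10A cells (Homo sapiens) for cytotoxicity, read by MTT assay, with a stated time of 72 h (on this read-out lower numbers stand for stronger inhibition and higher numbers for weaker inhibition), but only compound 2 has a number. Compound 3 therefore has no place on the scale, and neither does compound 1. Compound 4 `Cc1cc2occ(-c3nc(-c4ccccc4)c(-c4ccccc4)n3-c3ccc(Br)cc3)c(=O)c2cc1Cl` carries 4-bromophenyl in place of 3-nitrophenyl on an aromatic nitrogen. With no number for compound 3, the size and direction of this step cannot be measured. Going by the values given here, the only anchor is compound 2 at 98000 nM, and no shift beyond the usual scatter from that figure is expected. In this assay compound 4 is estimated at 70000 nM, with an expected range of 25000 nM to 180000 nM.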

Compound 4, half-maximal inhibitory concentration: > 100000 nM
Compound 4: no number, only a limit (the forecaster's own chance of this, stated with the estimate: 35%); middle value at least 1.4-fold (0.15 log units) away from the limit.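

For compound 4, this assay gives no number, only a limit: the limit of > 100000 nM in this assay, at which 1 of the 4 values shown sits. From the compounds shown here alone, with 4-bromophenyl in place of 3,4-dichlorophenyl on the aromatic nitrogen, the data give an at least 1.0-fold higher number from compound 2 to compound 4 (0.00 log units; that floor lies within the scatter), so this position has now taken a second halogen-bearing phenyl group, although the true size of the step stays unknown. Steps involving compound 1 or compound 3 cannot be read.

Going by these compounds, how far compound 4 lies past its limit remains open. So does whether an amine or a carboxylic acid on this phenyl group would bring the value within the measurable range.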